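Oxadiazole-linked imidazolines: aryl replacement at the five-membered ring

The source may hold more compounds than are shown below. What is called first, only, known or untested is meant among the compounds shown, and "the series" means these compounds.

Of the compounds shown here, three have numbers so far. Compound 1 `N#Cc1ccc(C2=NCCN2c2ccc(C(F)(F)F)cn2)cc1` gives 41800 nM in an assay for inhibition of Amine oxidase [flavin-containing] B (Homo sapiens), read by fluorescence and spectrophotometry, using microsomes, with stated times of 30 min and 20 min; on this read-out higher numbers stand for weaker inhibition and lower numbers for stronger inhibition. Compound 2 `Cc1nc(-c2ccc(C3=NCCN3)cc2)no1` gives 39700 nM in this assay. Compound 3 `CC(C)c1noc(-c2ccc(C3=NCCN3)cc2)n1` gives 230 nM in this assay, the lowest of the three numbers; its gaps to compound 2 and to compound 1 both lie beyond the scatter, so compound 3 is the strongest inhibitor measured here.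

Compound 4 `COc1cccc(-c2noc(-c3ccc(C4=NCCN4)cc3)n2)c1` has not been measured. It differs from compound 3 in one place: 3-methoxyphenyl in place of isopropyl on an aromatic carbon. No measured pair in the series isolates this kind of change, so nothing shown here tells how it will read out.

The expectation for compound 4 in this assay is a step of a 1.5-fold lower number from compound 3 to compound 4 (0.19 log units; within the scatter), near the scatter or only modestly beyond it, because compound 3 already sits at 230 nM while the smaller methyl analogue compound 2 sits at 39700 nM. Compound 4 is therefore estimated at 150 nM, with a range from 25 nM to 900 nM.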

Compound 4, half-maximal inhibitory concentration: 216 nM
Beside the measured number, compound 4's estimate is 1.4-fold (0.16 log units) below it, within the range that was stated.
By their numbers in this assay, from the lowest: compounds 4 and 3 (each within the scatter of the next); then compounds 2 and 1 (each within the scatter of the next).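

In this assay, 3-methoxyphenyl in place of isopropyl, on the aromatic carbon between two ring nitrogen atoms, gives a 1.1-fold lower number from compound 3 to compound 4 (0.03 log units; within the scatter), so compound 3 and compound 4 read alike. Going by these compounds alone, this position therefore accepts a group of 8 heavy atoms with a six-membered aromatic ring of carbon only, and the number stays level with that of the 3-heavy-atom isopropyl group, which the earlier compounds could not show. No measurement available here bears on why the two groups read alike.

Plain phenyl at this carbon would show whether the methoxy group contributes anything to the number of compound 4. Going by these compounds, it also remains open whether an amine or a carboxylic acid at this carbon would keep the number at this level.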